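The source may hold more compounds than are shown below. What is called first, only, known or untested is meant among the compounds shown, and "the series" means these compounds.

In a functional assay on MDA-MB-231 cells (Homo sapiens) for cytotoxicity, read by MTT assay, with a stated time of 48 h (a higher number here means a weaker inhibitor, a lower number a stronger inhibitor), compound 1, with the structure `COc1ccc(C2=NOC(COc3ccc(-c4nnnn4-c4cc(OC)c(OC)c(OC)c4)cc3N)C2)cc1N`, gives 3000 nM. Compound 2, with the structure `COc1ccc(C2=NOC(COc3ccc(-c4nnnn4-c4cc(OC)c(OC)c(OC)c4)cc3N)C2)cc1O`, differs from it only in that a hydroxy replaces an amino on an aromatic carbon, and in this assay compound 2 gives 3380 nM. The step of a 1.1-fold higher number from compound 1 to compound 2 (0.05 log units; within the scatter) lies within the scatter of repeated measurements, so on the two numbers available compound 2 and compound 1 cannot be told apart.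

Compound 3, with the structure `COc1ccc(C2=NOC(COc3ccc(-c4nnnn4-c4cc(OC)c(OC)c(OC)c4)cc3N)C2)cc1[N+](=O)[O-]`, is the next step from compound 2: nitro in place of hydroxy on an aromatic carbon. For the measured compounds named here, the only measured step touching this position, a 1.1-fold higher number from compound 1 to compound 2 (0.05 log units; within the scatter), concerns a hydroxy in place of an amino, and it did not move the number beyond the scatter. Going by the values given here, no measured pair shows a nitro in place of a hydroxy, so the new change is covered only loosely. Compound 3 is therefore expected to stay near compound 2, with a step of a 1.0-fold higher number from compound 2 to compound 3 (0.00 log units; within the scatter) and no direction favoured. The estimate for compound 3 is 3400 nM, in a range from 1400 nM to 8500 nM.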

Compound 3, half-maximal inhibitory concentration: 3560 nM
For compound 3 the middle estimate is 1.0-fold (0.02 log units) below the measured one, and the stated range covers the measured number.
By their numbers in this assay, from the lowest: compounds 1, 2 and 3 (each within the scatter of the next).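

Swapping hydroxy for nitro on this aromatic carbon, ortho to a methoxy group, gives a 1.1-fold higher number from compound 2 to compound 3 (0.02 log units; within the scatter) in this assay, and swapping amino for nitro gives a 1.2-fold higher number from compound 1 to compound 3 (0.07 log units; within the scatter). The earlier pair compared only amino and hydroxy, whereas this result adds a change of a different kind: the hydroxy that leaves carries a hydrogen-bond donor, and the nitro that enters carries none and has more heavy atoms, yet the number stays within the scatter, so the three compounds cannot be told apart in this assay. No supporting measurement is available to explain why these groups read alike.

As far as these compounds go, whether the same holds for other groups at this position, such as a carboxylic acid, a methyl group or a longer chain like propoxy, remains open, as does what plain hydrogen would give there. The second amino group, present in all three compounds, stays unchanged throughout, so these compounds also leave open what replacing it with hydroxy or nitro would do.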